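A 3-nitrophenyl swap at the assay limit

The source may report more compounds than this note shows. Statements on the series, on what has been measured and on what is new or still open speak of the compounds shown alone.

Four compounds share one core, and the numbers for them in a functional assay on A549 cells (Homo sapiens) for antiproliferative activity, read by MTT assay, with a stated time of 48 h (a lower number here means a stronger inhibitor, a higher number a weaker inhibitor), are few. Compound 3 `C#CCOC(=O)/C(C)=C/CC/C(C)=C/CC/C(C)=C/CC[C@@H]1[C@@]2(C)CCC(=O)C(C)(C)[C@H]2CC[C@@]1(C)O` gives a true number of 45100 nM. Compound 1 `C/C(=C\CC/C(C)=C/CC[C@@H]1[C@@]2(C)CCC(=O)C(C)(C)[C@H]2CC[C@@]1(C)O)CC/C=C(\C)C(=O)OCc1cn(-c2ccc([N+](=O)[O-])cc2)nn1` gives only a limit, > 150000 nM. Compound 2 `COc1ccccc1-n1cc(COC(=O)/C(C)=C/CC/C(C)=C/CC/C(C)=C/CC[C@@H]2[C@@]3(C)CCC(=O)C(C)(C)[C@H]3CC[C@@]2(C)O)nn1` also gives only a limit, > 150000 nM. Compound 2 therefore has no numeric value and stands at the limit of > 150000 nM in this assay, at which 2 of the 3 values shown sit.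

Compound 4 `C/C(=C\CC/C(C)=C/CC[C@@H]1[C@@]2(C)CCC(=O)C(C)(C)[C@H]2CC[C@@]1(C)O)CC/C=C(\C)C(=O)OCc1cn(-c2cccc([N+](=O)[O-])c2)nn1` is the next to be measured. It carries 3-nitrophenyl in place of 2-methoxyphenyl on an aromatic nitrogen of a five-membered aromatic ring with 3 nitrogen: 3-nitrophenyl in place of 2-methoxyphenyl on an aromatic nitrogen.

Going by the values given here, one measured step bears directly on this exchange, since it involves the same position and the same 2-methoxyphenyl group, there replacing 4-nitrophenyl: a step that the two limits leave unreadable from compound 1 to compound 2. It has no readable size and so offers neither a magnitude nor a direction. Among the compounds with values here, no measured step links compound 3 to this change. No shift beyond the scatter is therefore expected in this assay, and a second report of the limit is the likeliest outcome. The estimated step is a number no higher from compound 2 to compound 4 (the limit leaves the size open). For compound 4 the expected value is 150000 nM, with an estimated range from 70000 nM to 300000 nM.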

Compound 4, half-maximal inhibitory concentration: > 150000 nM
Compound 4: a limit, no number (the forecaster's own chance of this, stated with the estimate: 70%); the middle value sits exactly at the limit.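

In this assay compound 4 gives only a limit, > 150000 nM. No step can be read among compound 1, compound 2 and compound 4, since all three stand as limits and none has a number: the limit of > 150000 nM in this assay, at which 3 of the 4 values shown sit.

The compounds shown leave open how far compound 1, compound 2 and compound 4 actually differ in this assay.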